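The source may report more compounds than this note shows. Statements on the series, on what has been measured and on what is new or still open speak of the compounds shown alone.

Compound 1 `COc1ccc(Br)cc1Nc1cc(NC(=O)Nc2c(Cl)cccc2Cl)ncn1`: 69%. Compound 2 `CCc1ccc(Nc2cc(NC(=O)Nc3c(Cl)cccc3Cl)ncn2)cc1`: 70.1%. Compound 3 `CCc1cccc(Nc2cc(NC(=O)Nc3cc(OC)cc(OC)c3)ncn2)c1`: 82.1%.

All three were tested in a functional assay on PC-9 cells (Homo sapiens) for inhibition, read by MTT assay, with a stated time of 48 h, tested at 10 uM; a higher number here means more inhibition at the concentration tested (going by the name of the read-out), a lower number less inhibition. Among them compound 3 gives the highest number; compound 2 comes nearest, lower by more than the usual scatter, and compound 1 lies furthest away. Compound 4 `COc1cc(NC(=O)Nc2cc(Nc3cc(I)ccc3OC)ncn2)cc(OC)c1` has not yet been measured. It differs from compound 3 in one place: 5-iodo-2-methoxyphenyl in place of 3-ethylphenyl on a nitrogen on an aromatic ring. Going by the values given here, one measured step bears on this change, in the reverse direction and with bromine rather than iodine and 4-ethylphenyl rather than 3-ethylphenyl: a number 1.1 percentage points higher from compound 1 to compound 2 (within the scatter). On that basis no step beyond the scatter is expected in this assay: a number 4.1 percentage points lower from compound 3 to compound 4 (within the scatter). Compound 4 is therefore estimated at 78%, within a range from 62% to 90%.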

Compound 4, a percentage reported as inhibition, at one concentration (the size of the read-out at that concentration, not a potency): 91%
The estimate for compound 4 lay 13 percentage points below the measured number; the measured number lies above the stated range.
By their numbers in this assay, from the lowest: compounds 1 and 2 (each within the scatter of the next); then compounds 3 and 4 (each within the scatter of the next).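

At this position, on a nitrogen on an aromatic ring, 5-iodo-2-methoxyphenyl in place of 3-ethylphenyl gives a number 8.9 percentage points higher from compound 3 to compound 4 (within the scatter) in this assay. This second exchange of the group on that nitrogen, made on a different remainder of the molecule, again stays within the scatter, so the two quite different groups cannot be told apart here. No measurement at hand offers an explanation for this result. From the compounds shown here alone, the iodine and the methoxy enter together, so what each does alone remains unknown. Going by these compounds, how this position responds to an amine or a carboxylic acid on the ring also remains open.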